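Dichlorobenzyl in place of benzyl in the monoether

This account rests on a few compounds, and the source may have more. Where it says the series, first, only, none or still open, it means among the compounds named here.

The series is read in a functional assay on I10 cells (Mus musculus) for inhibition, read by MTT assay, with a stated time of 72 h; on this read-out lower numbers stand for stronger inhibition and higher numbers for weaker inhibition. Among the measured compounds shown here, compound 1, the bis-ether `C=CCc1ccc(OCc2ccc(Cl)cc2Cl)c(-c2ccc(OCc3ccc(Cl)cc3Cl)c(CC=C)c2)c1`, is the only member whose read-out is a limit of the assay rather than a number: compound 1 gives > 50000 nM in this assay. For the measured compounds named here, compound 2, the monoether with a free phenol `C=CCc1ccc(O)c(-c2ccc(OCc3ccccc3)c(CC=C)c2)c1`, gives 29800 nM in this assay, the only numerical value shown in the set. Going by the values given here, no pair of measured compounds differs in a single place, so no measured step is available; the set rests on one number and one limit, the limit being (the limit of > 50000 nM in this assay, at which 1 of the 2 values shown sits).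

Compound 3 `C=CCc1ccc(O)c(-c2ccc(OCc3ccc(Cl)cc3Cl)c(CC=C)c2)c1` is not yet measured. It differs from compound 2 by 2,4-dichlorophenyl in place of phenyl on a saturated chain carbon bound to an oxygen on an aromatic ring. Compound 3 keeps the free phenol of compound 2 and takes up the 2,4-dichlorobenzyl group of compound 1.

Because compound 1 gives > 50000 nM, the dichlorinated ether has so far produced only a limit. Compound 3 is therefore expected to lie near the weak end, with a step of a 1.3-fold higher number from compound 2 to compound 3 (0.11 log units; within the scatter) at most within or slightly beyond the scatter. The estimate for compound 3 is 38000 nM, between 12000 nM and 120000 nM.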

Compound 3, half-maximal inhibitory concentration: 10400 nM
For compound 3 the middle estimate is 3.7-fold (0.56 log units) above the measured one; measured number below the stated range.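

In this assay, the 2,4-dichlorobenzyl group now has a number in the setting of the free phenol, where compound 1 had given only a limit. At the saturated chain carbon bound to an oxygen on an aromatic ring, 2,4-dichlorophenyl in place of phenyl gives a 2.9-fold lower number from compound 2 to compound 3 (0.46 log units; beyond the scatter), so the two chlorines are tolerated here and bring a modest gain on this read-out rather than the loss that the bis-ether alone might have suggested. On the other oxygen on an aromatic ring, hydrogen in place of 2,4-dichlorobenzyl gives an at least 4.8-fold lower number from compound 1 to compound 3 (0.68 log units; beyond the scatter), which places the monoether ahead of the bis-ether, though the true size of this step stays unknown, as compound 1 is a limit of the assay and not a number: the limit of > 50000 nM in this assay, at which 1 of the 3 values shown sits.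

Still open, on these data alone, is whether a single chlorine, as in a 4-chlorobenzyl or 2-chlorobenzyl ether, would give the same step as the two chlorines together. Also open, as far as these compounds go, is whether the free phenol itself matters once the dichlorobenzyl ether is in place, which a methyl ether or an aminoethyl ether on that oxygen would test.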